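This account rests on a few compounds, and the source may have more. Where it says the series, first, only, none or still open, it means among the compounds named here.

Measured in a functional assay on A549 cells (Homo sapiens) for antiproliferative activity, read by sulforhodamine B assay, with a stated time of 48 h; on this read-out lower numbers stand for stronger inhibition and higher numbers for weaker inhibition:
- Compound 1 `COc1cccc(/C=C/C(=O)/C=C(O)/C=C/c2cccc(OC)c2OC)c1OC`: 11500 nM
- Compound 2 `COc1cccc(/C=C/C(=O)C(=Cc2ccc(F)cc2)C(=O)/C=C/c2cccc(OC)c2OC)c1OC`: 340 nM
- Compound 3 `COc1cccc(/C=C/C(=O)C(=Cc2cc(OC)c(OC)c(OC)c2)C(=O)/C=C/c2cccc(OC)c2OC)c1OC`: 230 nM

Compound 3 gives 230 nM, which cannot be told apart from compound 2 at 340 nM. Compound 1 stands far higher at 11500 nM.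

Compound 4 `COc1cccc(/C=C/C(=O)C(=Cc2ccc(O)c(F)c2)C(=O)/C=C/c2cccc(OC)c2OC)c1OC` keeps the core of compound 3 but carries 3-fluoro-4-hydroxyphenyl in place of 3,4,5-trimethoxyphenyl on a double-bonded chain carbon bound to a double-bonded chain carbon.

Within the data shown here, only one measured step touches this place. That step, a 1.5-fold lower number from compound 2 to compound 3 (0.17 log units; within the scatter), exchanged 4-fluorophenyl for 3,4,5-trimethoxyphenyl and stayed within the scatter. Two quite different groups at this place thus gave values in the same range, so no step beyond the scatter is expected in this assay, in either direction. Among the measured compounds shown here, no measured compound has a 3-fluoro-4-hydroxyphenyl group, so the range must stay wide.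

The estimated change is a 1.3-fold higher number from compound 3 to compound 4 (0.12 log units; within the scatter). For compound 4 the expected value is 300 nM, with an estimated range from 100 nM to 1000 nM.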

Compound 4, half-maximal inhibitory concentration: 200 nM
Compound 4: middle estimate off by 1.5-fold (0.18 log units), on the high side; low and high end bracket the measured number.
By their numbers in this assay, from the lowest: compounds 4, 3 and 2 (each within the scatter of the next); then compound 1.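

In this assay, a third substituted phenyl group at this place gives a value in the same range: a 1.2-fold lower number from compound 3 to compound 4 (0.06 log units; within the scatter), and a 1.7-fold lower number from compound 2 to compound 4 (0.23 log units; within the scatter), both within the scatter. The entering 3-fluoro-4-hydroxyphenyl has fewer heavy atoms than the 3,4,5-trimethoxyphenyl it replaces and, unlike it, carries a hydrogen-bond donor, yet neither difference goes with a step beyond the scatter. No independent evidence is available to interpret this result.

All the groups shown at this place on the shared core are substituted phenyl rings, so it remains open whether an amine, a carboxylic acid or a longer chain would stay in this range. The separate contributions of the hydroxyl and the fluorine also remain open, as a phenyl ring carrying only the hydroxyl is not among these compounds.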